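The source may report more compounds than this note shows. Statements on the series, on what has been measured and on what is new or still open speak of the compounds shown alone.

Compound 1 `C=CCNC(=O)n1c(-c2ccc(OC)cc2)cc(=O)c2c(OC)cc(OC)cc21` and compound 2 `COc1cc(OC)c2c(=O)cc(C(=O)Nc3cccc(N4CCCC4)c3)[nH]c2c1` were both examined in a functional assay on KOPN-8 cells (Homo sapiens) for antiproliferative activity, with a stated time of 72 h; on this read-out higher numbers stand for an effect only at larger amounts of compound and lower numbers for an effect already at smaller amounts. In this assay compound 1 gives 12000 nM. For compound 2 this assay returns only a limit, > 58600 nM, so no number stands for it. Compound 2 therefore sits at the edge of what is shown: the limit of > 58600 nM in this assay, at which 1 of the 2 values shown sits, while compound 1 is the only one of the two with a measured number. Compound 3 `COc1cc(OC)c2c(=O)cc(C(=O)Nc3cccc(-c4nccs4)c3)[nH]c2c1` has not yet been measured in this assay. Compound 3 differs from compound 2 in one place: 1,3-thiazol-2-yl in place of pyrrolidin-1-yl on an aromatic carbon. Among the measured compounds shown here, no measured pair in the set shows what such an exchange does in this assay, and the limit of compound 2 gives no firm number from which a step could be counted. The expected step from compound 2 to compound 3 is an at least 2.3-fold lower number from compound 2 to compound 3 (0.36 log units; beyond the scatter), estimated as modest and toward lower values, with a real chance that compound 3 again returns only a limit. In this assay compound 3 is expected to give 25000 nM, within a range from 5000 nM to 120000 nM.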

Compound 3, half-maximal effective concentration: > 54000 nM
Compound 3: no number, only a limit; the forecaster's own chance of this, stated with the estimate: 50%; middle value at least 2.1-fold (0.33 log units) away from the limit.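

Like compound 2, compound 3 returns only a limit in this assay, > 54000 nM, so the step between the two cannot be read. The compounds shown leave open what 1,3-thiazol-2-yl in place of pyrrolidin-1-yl on an aromatic carbon does in this assay, and whether either compound would give a number there at all.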